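The compounds below may be only part of what the source reports. "The series", "measured", "known", "first", "only" and "open" are said of these compounds alone.

Three compounds have so far been measured in a functional assay, tested at 200 ug/mL; a higher number here means a stronger effect of the compound at the concentration tested, a lower number a weaker effect:

compound 1, `COc1cc(Br)c(C2C(C#N)=C(N)OC(c3c[nH]c4ccccc34)=C2C#N)cc1OC`: 24.2%
compound 2, `COc1ccc(C2C(C#N)=C(N)OC(c3c[nH]c4ccccc34)=C2C#N)cc1OC`: 26.1%
compound 3, `Cc1ccccc1C1C(C#N)=C(N)OC(c2c[nH]c3ccccc23)=C1C#N`: 21.4%

Compound 3 gives the smallest of the three numbers, yet both compound 1 and compound 2 lie within the usual scatter of it, so no order among them can be claimed. Compound 4, `N#CC1=C(N)OC(c2c[nH]c3ccccc23)=C(C#N)C1c1cccc2ccccc12`, has not yet been measured in this assay. It differs from compound 3 in one place: naphthalen-1-yl in place of 2-methylphenyl on a saturated ring carbon. For the measured compounds named here, the only measured step at this position, a number 4.7 percentage points lower from compound 2 to compound 3 (within the scatter), stayed within the scatter, and the step of a number 1.9 percentage points higher from compound 1 to compound 2 (within the scatter), at another position, did likewise. The data therefore offer no reason to expect a move in this assay beyond the scatter; compound 4 is estimated at 23%, with a range from 12% to 34%. The expected step is a number 1.6 percentage points higher from compound 3 to compound 4 (within the scatter), which means a number indistinguishable from that of compound 3.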

Compound 4, a percentage reported as activity, at one concentration (the size of the read-out at that concentration, not a potency): 7.7%
Estimate against measurement, compound 4: 15.3 percentage points above; the whole stated range lies above it.
By their numbers in this assay, from the lowest: compound 4; then compounds 3, 1 and 2 (each within the scatter of the next).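

In this assay, the saturated ring carbon now proves sensitive to the group it carries: the change to naphthalen-1-yl gives a number 13.7 percentage points lower from compound 3 to compound 4 (beyond the scatter), and the comparison with the dimethoxy analogue gives a number 18.4 percentage points lower from compound 2 to compound 4 (beyond the scatter). The earlier step at this position, between 3,4-dimethoxyphenyl and 2-methylphenyl, stayed within the scatter, so the aryl group here is not interchangeable, at least once naphthalen-1-yl with its two six-membered aromatic rings enters. Nothing available bears on what lies behind this fall.

With only three groups compared at this carbon, the compounds shown leave open whether the second aromatic ring itself accounts for the lower number. They also do not show how an unsubstituted phenyl, or a phenyl carrying an amine or a carboxylic acid, would read at this position.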